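Oxanyl ether on the urea aryl of compound 2

The compounds below may be only part of what the source reports. "The series", "measured", "known", "first", "only" and "open" are said of these compounds alone.

Working notes. The series is tested in a functional assay on CHO cells for antagonist activity at C-X-C chemokine receptor type 3 (Homo sapiens), read by GTPgammaS binding; a lower number here means a stronger inhibitor, a higher number a weaker inhibitor. Compound 2 `CC1(C)[C@H]2CC=C(CN3CCC(NC(=O)Nc4ccccc4)CC3)[C@@H]1C2` gives 2000 nM, the highest number of the three measured here; compound 1 `COC(=O)c1cccc(NC(=O)NC2CCN(C/C3=C/CCCCCC3)CC2)c1` gives 660 nM, and compound 3 `CC1(C)[C@H]2CC=C(CN3CCC(NC(=O)Nc4cncc(Br)c4)CC3)[C@@H]1C2` gives 171 nM. Compounds 1 and 2 differ in more than one place, so their values are only set side by side. For the measured compounds named here, the one single-point step known is a 12-fold lower number from compound 2 to compound 3 (1.07 log units; beyond the scatter), a large move from changing the aryl on the urea.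

Compound 4 `CC1(C)[C@H]2CC=C(CN3CCC(NC(=O)Nc4cccc(OC5CCOCC5)c4)CC3)[C@@H]1C2` is not yet measured. It differs from compound 2 as follows: (oxan-4-yl)oxy in place of hydrogen on an aromatic carbon. Going by the values given here, no measured step covers this exact change; the nearest evidence is the urea-aryl step from compound 2 to compound 3, which shows that the aryl end tolerates substitution with a large gain, while compound 1 shows that a substituted phenyl urea on a different core also sits well below compound 2.

For compound 4 a moderate lowering is therefore expected, around a 2.9-fold lower number from compound 2 to compound 4 (0.46 log units; beyond the scatter). The estimate for compound 4 is 700 nM, with a range from 200 nM to 2500 nM.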

Compound 4, inhibition constant: 191 nM
Beside the measured number, compound 4's estimate is 3.7-fold (0.56 log units) above it, and the stated range ends above it.
By their numbers in this assay, from the lowest: compounds 3 and 4 (each within the scatter of the next); then compound 1; then compound 2.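

In this assay, a 10-fold lower number from compound 2 to compound 4 (1.02 log units; beyond the scatter) is the step for adding (oxan-4-yl)oxy to an aromatic carbon, meta to a large group, and it shows that the phenyl urea itself can carry this substituent with a large gain. The earlier step, a 12-fold lower number from compound 2 to compound 3 (1.07 log units; beyond the scatter), replaced phenyl with 5-bromopyridin-3-yl, so the new step shows that a large gain at this end of the series needs neither a ring nitrogen nor bromine. Nothing available explains the gain.

Going by these compounds, whether it depends on the whole oxan-4-yl ring or only on the ether oxygen stays open, and a methoxy or hydroxy group on the same aromatic carbon would help separate the two. Also open, on these data alone, is whether a basic group, such as an aminoalkoxy chain, would be tolerated there.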